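The source may report more compounds than this note shows. Statements on the series, on what has been measured and on what is new or still open speak of the compounds shown alone.

Measured so far in a functional assay on HeLa cells (Homo sapiens) for inhibition, with a stated time of 72 h; on this read-out lower numbers stand for an effect already at smaller amounts and higher numbers for an effect only at larger amounts of compound:

compound 1 `COc1cc(CNCc2ccncc2)ccc1OCc1cccc(F)c1`: 4800 nM
compound 2 `COc1cc(CNCc2ccncc2)ccc1OCc1cnc(Cl)c(Cl)c1`: 220 nM
compound 3 `COCCNCc1ccc(OCc2ccc(Cl)nc2)c(OC)c1`: 97000 nM

Compound 3 gives the highest number of the three in this assay. Its nearest neighbour is compound 1, which gives a markedly lower number, and the gap to compound 2 is wider still. Compound 4 `COc1cc(CNCCSc2nnnn2C)ccc1OCc1ccc(Cl)nc1` is not yet measured. It arises from compound 3 by the change ((1-methyl-1H-tetrazol-5-yl)sulfanyl in place of methoxy on a saturated chain carbon, two bonds along the chain from an amine nitrogen).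

Within the data shown here, the only step measured between two compounds that differ in a single place is a 22-fold lower number from compound 1 to compound 2 (1.34 log units; beyond the scatter). That step sits on a different part of the molecule, the group on the saturated chain carbon bound to an oxygen on an aromatic ring, so it says nothing direct about a change on the chain at the amine nitrogen. Compound 1 and compound 3 differ in more than one place, so their values only show that the two substitution patterns together span a wide gap. Among the measured compounds shown here, there is therefore no measured precedent for this change, and the expectation rests on the shared core of compound 3 alone. Compound 4 is estimated at 25000 nM, within 5000 nM to 120000 nM, which means an expected step of a 3.9-fold lower number from compound 3 to compound 4 (0.59 log units; beyond the scatter).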

Compound 4, half-maximal effective concentration: 86000 nM
Compound 4: the middle estimate sits 3.4-fold (0.54 log units) below what was measured; the measured number falls inside the stated range.
By their numbers in this assay, from the lowest: compound 2; then compound 1; then compounds 4 and 3 (each within the scatter of the next).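

In this assay, replacing methoxy with (1-methyl-1H-tetrazol-5-yl)sulfanyl on the saturated chain carbon, two bonds along the chain from an amine nitrogen, gives a 1.1-fold lower number from compound 3 to compound 4 (0.05 log units; within the scatter). This first direct test of the position shows that a bigger group carrying a five-membered aromatic ring and a plain methoxy cannot be told apart here, so this change gives no measurable gain or loss on this core. Nothing available explains this outcome.

From the compounds shown here alone, it remains open whether a carboxylic acid, an amine or a longer chain at this carbon would shift the number beyond the scatter. Also open, going by these compounds, is whether 5,6-dichloropyridin-3-yl on the core of compound 4 would give a lower number.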